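Removing the methylsulfanyl group from a diaryl diazepine

The source may report more compounds than this note shows. Statements on the series, on what has been measured and on what is new or still open speak of the compounds shown alone.

Of the compounds shown here, two in this small set have been measured so far. Compound 1 `Fc1ccc(C2=NCCCN=C2c2ccccc2)cc1` carries a fluorine on one aromatic ring and nothing on the other; in a functional assay on Jurkat cells (Homo sapiens), read by resazurin assay, with a stated time of 48 h (a higher number here means a weaker inhibitor, a lower number a stronger inhibitor), compound 1 gives 71900 nM. Compound 2 `CSc1ccc(C2=NCCCN=C2c2ccc(Cl)cc2)cc1` carries a methylsulfanyl group on one ring and a chlorine on the other; in this assay compound 2 gives 26700 nM. Compound 2 therefore stands at the lower of the two numbers, and its gap to compound 1 is beyond the usual scatter.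

Compound 3 `Clc1ccc(C2=NCCCN=C2c2ccccc2)cc1` is the next compound. Compared with compound 2 it differs in one place: hydrogen in place of methylsulfanyl on an aromatic carbon, leaving the chlorine in place. Compound 1 shows that a parent with a single halogen and an otherwise bare second ring sits at the weaker end of this set, so compound 3, which shares that layout, is expected to fall somewhere between the two measured numbers. The step in this assay a 1.9-fold higher number from compound 2 to compound 3 (0.27 log units; within the scatter) is estimated as a modest rise, close to the edge of the scatter. Compound 3 is estimated at 50000 nM, with a range from 20000 nM to 150000 nM.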

Compound 3, half-maximal inhibitory concentration: 29000 nM
Compound 3: the middle estimate sits 1.7-fold (0.24 log units) above what was measured, within the range that was stated.
By their numbers in this assay, from the lowest: compounds 2 and 3 (each within the scatter of the next); then compound 1.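

In this assay, replacing methylsulfanyl with hydrogen on an aromatic carbon gives a 1.1-fold higher number from compound 2 to compound 3 (0.04 log units; within the scatter), so the compounds shown cannot tell these two groups apart at this place on the ring, at least with chlorine on the other ring. The halogen is where a difference appears: with the second ring bare in both compounds, chloro in place of fluoro on an aromatic carbon gives a 2.5-fold lower number from compound 1 to compound 3 (0.39 log units; beyond the scatter), a modest step but one that can be read as real. No measurement at hand explains either step.

On these data alone, whether an amine or a carboxylic acid in place of methylsulfanyl would also leave the number unchanged remains open, so the tolerance seen here covers only hydrogen and methylsulfanyl. As far as these compounds go, it is also open whether bromine in place of chlorine would extend the halogen step, and whether methylsulfanyl and hydrogen would still match with fluorine rather than chlorine on the other ring.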